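This account rests on a few compounds, and the source may have more. Where it says the series, first, only, none or still open, it means among the compounds named here.

The compounds here share one core with a pendant aromatic ring at the far end, as in compound 1 `O=C1c2ccc(OCc3cccc(-c4ccc(Cl)cc4F)c3)cc2CN1C1CCCC1`, compound 2 `O=C(O)c1cc(-c2cccc(COc3ccc4c(=O)n(CC5CC5)sc4c3)c2)ccc1Cl` and compound 3 `O=C1c2ccc(OCc3cccc(-c4ccc(C(F)(F)F)cc4F)c3)cc2CN1C1CCCC1`; what changes from one to the next is the substitution on that outer ring. Only one of the three has a number. In an assay on HEK293 cells for positive allosteric modulation of metabotropic glutamate receptor 2 (Rattus norvegicus), read by thallium flux (on this read-out higher numbers stand for larger maximal responses and lower numbers for smaller maximal responses), compound 2 gives 38.4%. In this assay compound 3 stands as "not determined" (no result reported), and compound 1 stands as "not determined" (no result reported), so compound 3 cannot be placed against any measured neighbour on this read-out.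

Compound 4 `O=C(O)c1cc(F)cc(-c2cccc(COc3ccc4c(c3)CN(C3CCCC3)C4=O)c2)c1` is the compound still to be measured. It differs from compound 3 in a single place: 3-carboxy-5-fluorophenyl in place of 2-fluoro-4-(trifluoromethyl)phenyl on an aromatic carbon.

Within the data shown here, no pair of measured compounds differs in one place, so the size of the step from compound 3 to compound 4 in this assay cannot be read from a comparable step. I expect neither a clear rise nor a clear fall, only a change that may or may not exceed the usual scatter. Among the measured compounds shown here, the one anchor is compound 2, which also carries a carboxy group on its outer ring and which is relevant because in this assay compound 2 gives 38.4%. For compound 4 the expected maximal response in this assay is estimated at 45%, with a range from 20% to 80%.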

Compound 4, largest response reached (reported as percent of maximum), in percent of the reference or control that the assay uses: 80.8%
The estimate for compound 4 lay 35.8 percentage points below the measured number, outside the stated range (above it).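

No step can be read from this result. In this assay compound 3 stands as "not determined" (no result reported) and so gives compound 4 no measured neighbour that differs in one place. The compounds shown leave open how far the change of outer ring alone moves the maximal response. Nothing here gives a measured explanation for the value of compound 4.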